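Replacing the Cyclopropylcarbamoyl Group of Compound 3

The source may hold more compounds than are shown below. What is called first, only, known or untested is meant among the compounds shown, and "the series" means these compounds.

In a functional assay on LNCaP cells (Homo sapiens) for antiproliferative activity (a lower number here means a stronger inhibitor, a higher number a weaker inhibitor), compound 1 (`Cn1ncc(Cl)c1-c1cc(C(=O)N[C@@H]2CN[C@H](CCN3CCC(O)CC3)C[C@H]2c2ccc(Cl)c(Cl)c2)oc1Cl`) gives 1140 nM and compound 2 (`CN(C)CC[C@@H]1C[C@@H](c2ccc(Cl)c(Cl)c2)[C@H](NC(=O)c2cc(-c3c(Cl)cnn3C)c(Cl)o2)CN1`) gives 1930 nM on the shared core. Between them lies a 1.7-fold higher number from compound 1 to compound 2 (0.23 log units; within the scatter) and no more. Compound 3 (`Cn1ncc(Cl)c1-c1cc(C(=O)N[C@@H]2CN[C@H](CC(=O)NC3CC3)C[C@H]2c2ccc(Cl)c(Cl)c2)oc1Cl`) holds the lowest number of the three at 190 nM in this series. Compound 4 (`COCC[C@@H]1C[C@@H](c2ccc(Cl)c(Cl)c2)[C@H](NC(=O)c2cc(-c3c(Cl)cnn3C)c(Cl)o2)CN1`) carries methoxymethyl in place of cyclopropylcarbamoyl on a saturated chain carbon bound to a saturated ring carbon. For the measured compounds named here, no measured step makes this exchange directly. The nearest guides are a 6.0-fold lower number from compound 1 to compound 3 (0.78 log units; beyond the scatter) and a 10-fold lower number from compound 2 to compound 3 (1.01 log units; beyond the scatter) as steps that install cyclopropylcarbamoyl. Compound 4 lacks that group, yet also lacks dimethylamino and 4-hydroxypiperidin-1-yl. A small rise is therefore expected, namely a 2.1-fold higher number from compound 3 to compound 4 (0.32 log units; beyond the scatter) in this assay by this estimate. Compound 4 is estimated at 400 nM with an expected range from 130 nM to 1200 nM in all.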

Compound 4, half-maximal inhibitory concentration: 250 nM
Compound 4: middle estimate off by 1.6-fold (0.20 log units), on the high side, within the range that was stated.
By their numbers in this assay, from the lowest: compounds 3 and 4 (each within the scatter of the next); then compounds 1 and 2 (each within the scatter of the next).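

In this assay, the cyclopropylcarbamoyl group proves dispensable at this position: methoxymethyl, with no ring and no hydrogen-bond donor, stands level with it (a 1.3-fold higher number from compound 3 to compound 4 (0.12 log units; within the scatter)). The earlier compounds shown here could not show that this group was not the deciding feature; instead, the two amines stand apart from methoxy (a 7.7-fold lower number from compound 2 to compound 4 (0.89 log units; beyond the scatter); a 4.6-fold lower number from compound 1 to compound 4 (0.66 log units; beyond the scatter)). No measurement given here explains these differences.

Whether the ether oxygen matters remains open, since the compounds shown include no all-carbon chain at this place. A carboxylic acid there is equally untested by the compounds shown.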